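The compounds below may be only part of what the source reports. "The series", "measured", "known", "first", "only" and "open" are said of these compounds alone.

Measured so far in a functional assay on SW-620 cells (Homo sapiens) for inhibition; on this read-out higher numbers stand for weaker inhibition and lower numbers for stronger inhibition:
Compound 1 `CCC(C)C1NC(=O)N(C2CCCC2)C1=O` gives > 100000 nM, a limit of the assay.
Compound 2 `CC(C)C(NC(=O)NO)C(=O)NC1CCCC1` gives > 100000 nM, likewise a limit.
Compound 3 `CC(C)C1NC(=O)N(C2CCCC2)C1=O` gives > 100000 nM, again a limit.

All three values sit at the limit of > 100000 nM in this assay, at which 3 of the 3 values shown sit. From compound 3 to compound 1 the change is methyl in place of hydrogen on a saturated chain carbon, two bonds along the chain from a saturated ring carbon, and the step that the two limits leave unreadable from compound 3 to compound 1 cannot be read, as both ends are limits. How the core of compound 2 differs from the core of compound 3 is not broken down here. Compound 4 `CCC(C)C(NC(=O)NO)C(=O)NC1CCCC1`, still unmeasured, differs from compound 2 by methyl in place of hydrogen on a saturated chain carbon, three bonds along the chain from an amide-type nitrogen and a carbonyl carbon. This is the same kind of change as from compound 3 to compound 1, but the place differs: there it lies two bonds along the chain from a saturated ring carbon, here three bonds along the chain from an amide-type nitrogen and a carbonyl carbon. Compound 2 shows only the limit > 100000 nM. Since the related step that the two limits leave unreadable from compound 3 to compound 1 is unreadable, the step from compound 2 to compound 4 is expected to be a number no higher from compound 2 to compound 4 (the limit leaves the size open). In this assay compound 4 is therefore estimated at 100000 nM, between 30000 nM and 300000 nM, most likely reported again as a limit.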

Compound 4, half-maximal inhibitory concentration: > 100000 nM
Compound 4 ended at the assay's limit (the forecaster's own chance of this, stated with the estimate: 85%); the middle value sits exactly at the limit.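

In this assay, going by these compounds alone, compound 4 gives > 100000 nM, a limit, and no step from compound 2, itself at a limit, can be read. The compounds shown leave open how strongly any of them inhibits, and whether methyl in place of hydrogen changes that at all: the limit of > 100000 nM in this assay, at which 4 of the 4 values shown sit.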